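Adding a Third Methoxy Group to Compound 3

The compounds below may be only part of what the source reports. "The series", "measured", "known", "first", "only" and "open" are said of these compounds alone.

Of the compounds shown here, three built on a shared core have been tested in a functional assay for inhibition, with a stated time of 5 min, tested at 1 mM; a lower number here means less inhibition, a higher number more inhibition at the concentration tested (going by the name of the read-out). Compound 1 `COc1cc(/C(Cl)=C/C=C(\C#N)C(=O)c2c[nH]c3ccccc23)cc(OC)c1OC` gives 59.1%. Among the measured compounds shown here, compound 2 `COc1cc(/C(Cl)=C/C=C(\C#N)C(=O)c2c[nH]c3ccc(Br)cc23)cc(OC)c1OC` gives 50%, and the only single change among the measured pairs, a number 9.1 percentage points lower from compound 1 to compound 2 (within the scatter), stays within the scatter. Compound 3 `COc1ccc(/C(Cl)=C/C=C(\C#N)C(=O)c2c(C)[nH]c3ccccc23)cc1OC` gives 66.4%, the highest of the three numbers; it sits within the scatter of compound 1 but clearly above compound 2.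

Compound 4 `COc1cc(/C(Cl)=C/C=C(\C#N)C(=O)c2c(C)[nH]c3ccccc23)cc(OC)c1OC` differs from compound 3 in one place: methoxy in place of hydrogen on an aromatic carbon. For the measured compounds named here, no measured step covers this exact change. Compound 1 and compound 3 differ in two places at once, so their values only show that the two patterns of methoxy groups give numbers within the scatter of each other. Going by the values given here, the one measured step, bromo for hydrogen, also stayed within the scatter. Compound 4 is therefore expected to show a step of about a number 4.4 percentage points lower from compound 3 to compound 4 (within the scatter), nothing beyond the scatter. Compound 4 is estimated at 62%, in the range 48% to 76%.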

Compound 4, a percentage reported as inhibition, at one concentration (the size of the read-out at that concentration, not a potency): 58.2%
The estimate for compound 4 lay 3.8 percentage points above the measured number, within the range that was stated.
By their numbers in this assay, from the lowest: compounds 2, 4, 1 and 3 (each within the scatter of the next, the first and the last beyond it).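

In this assay, among the compounds shown here, this is the first direct reading of methoxy in place of hydrogen on this aromatic carbon, and a number 8.2 percentage points lower from compound 3 to compound 4 (within the scatter) shows that the added group makes no change that can be told from the scatter. With the same three methoxy groups on the ring of carbon only, the two other single changes also stay small: a methyl group taking the place of a hydrogen gives a number 0.9 percentage points lower from compound 1 to compound 4 (within the scatter) and 2-methyl-1H-indol-3-yl in place of 5-bromo-1H-indol-3-yl gives a number 8.2 percentage points higher from compound 2 to compound 4 (within the scatter) in the same read-out. Nothing measured here offers an explanation for these numbers.

Each number comes from one concentration, so how the potencies of these compounds compare stays open. Also open, on these data alone, is whether an amine or an ethoxy group at this position would give a step beyond the scatter.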